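Ethyl for acetyl on the aryl hydrazone: series notes

A few compounds are considered here, and "the series" means these few. Any claim that something is new, unique, unknown or untested is made for them only; others in the source may bear on it.

Measured so far in a functional assay on the whole organism for inhibition, with Rattus norvegicus as the target; on this read-out higher numbers stand for an effect only at larger amounts of compound and lower numbers for an effect already at smaller amounts:
compound 1 `CC1CC/C(=N\Nc2ccc(Br)cc2)c2ncc(C(=O)O)c(=O)n21` gives only a limit, > 1000 umol/kg.
compound 2 `CC(=O)c1ccc(N/N=C2\CCC(C)n3c2ncc(C(=O)O)c3=O)cc1` gives only a limit, > 100 umol/kg.

Compound 2 thus stands at a limit of this assay, not at a number. Within the data shown here, the only measured step, a step that the two limits leave unreadable from compound 1 to compound 2, is likewise bounded by limits and gives no readable size. Compound 3 `CCc1ccc(N/N=C2\CCC(C)n3c2ncc(C(=O)O)c3=O)cc1` differs from compound 2 by ethyl in place of acetyl on an aromatic carbon. With no readable step to draw on, no change beyond the scatter is assumed, and compound 3 is expected to return a limit again. The estimate for compound 3 is 300 umol/kg, with a range from 60 umol/kg to 3000 umol/kg. The expected step is a step that the limit leaves unreadable from compound 2 to compound 3.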

Compound 3, dose for 50% inhibition: > 1000 umol/kg
Compound 3 ended at the assay's limit (the forecaster's own chance of this, stated with the estimate: 85%); middle value at least 3.3-fold (0.52 log units) away from the limit.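

In this assay compound 3 gives > 1000 umol/kg, a limit and not a number. Among these compounds, no step among compound 1, compound 2 and compound 3 can be read. The compounds shown leave open whether bromo, acetyl or ethyl on that aromatic carbon makes any difference.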